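Chloro Addition on a Stable Pyridyl Ether Series

The compounds below may be only part of what the source reports. "The series", "measured", "known", "first", "only" and "open" are said of these compounds alone.

Three compounds were measured in an ADME assay on microsomes from liver (Homo sapiens) for metabolic stability, read by LC-MS, using NADPH, with a stated time of 10 min, tested at 0.5 uM; on this read-out higher numbers stand for a more stable compound and lower numbers for a less stable compound. Compound 1 `COC(=O)Nc1cc(-c2ccc(OC[C@@](C)(N)CC(C)C)cn2)ccn1` gives 93%. Compound 2 `COC(=O)Nc1cc(-c2cnc(OC[C@@](C)(N)CC(C)C)c(Cl)c2)ccn1` gives 90% in this assay, and compound 3 `COC(=O)Nc1cc(-c2ccc(OC[C@@](C)(N)CC(C)C)nc2)ccn1` gives 100%. Compound 3 and compound 2 differ in one place, (chloro in place of hydrogen on an aromatic carbon), and this change produced a number 10 percentage points lower from compound 3 to compound 2 (within the scatter). How the cores of compound 1 and compound 3 differ is not broken down here.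

Compound 4 `COC(=O)Nc1cc(-c2ccc(OC[C@@](C)(N)CC(C)C)c(Cl)n2)ccn1` has not yet been measured in this assay. It differs from compound 1 by chloro in place of hydrogen on an aromatic carbon, which is the same kind of change as that from compound 3 to compound 2, though its place is not identical: in compound 4 the chloro sits next to the ring nitrogen, whereas in compound 2 it sits two atoms from the ring nitrogen. Because compound 1 gives 93% and the related change gave a number 10 percentage points lower from compound 3 to compound 2 (within the scatter), the step from compound 1 to compound 4 is expected to be small, a number 5 percentage points lower from compound 1 to compound 4 (within the scatter). Compound 4 is therefore estimated at 88%, between 74% and 98%.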

Compound 4, percent of the compound remaining: 93%
For compound 4 the middle estimate is 5 percentage points below the measured one, within the range that was stated.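

Putting chloro in place of hydrogen on an aromatic carbon of the core of compound 1 gave no change at the digits printed from compound 1 to compound 4 (within the scatter) in this assay. Set beside the earlier step on the other core, the two readings of this change do not differ beyond what repeated measurements allow: the same change on two cores in this assay, a number 10 percentage points lower (within the scatter) from compound 3 to compound 2 and no change at the digits printed (within the scatter) from compound 1 to compound 4, 10 percentage points apart, within the scatter of two such steps
This shows only that, in these two pairs, the change was carried between cores without a step beyond the scatter; it does not show that chloro is without effect in general, as the chloro does not stand at the same place on the two cores and the parents sit high on the scale, with compound 1 at 93% and compound 3 at 100%.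

The compounds shown leave open whether fluoro, methyl or a nitrile in place of the chloro would read the same. They also leave open whether the step would hold if the (2-amino-2,4-dimethylpentyl)oxy group carried a shorter chain, or an amide in place of its amine.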